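The source may hold more compounds than are shown below. What is called first, only, known or untested is meant among the compounds shown, and "the series" means these compounds.

Working notes on the series.

Three compounds have been run in a functional assay on A549 cells (Homo sapiens) for antiproliferative activity, read by MTT assay, with a stated time of 72 h; a lower number here means a stronger inhibitor, a higher number a weaker inhibitor. Compound 2 `N=C(NS(=O)(=O)c1ccccc1C(F)(F)F)N1CCN(c2cc3c(cc2F)c(=O)c(C(=O)O)cn3C2CC2)CC1` gives 71 nM. Compound 1 `N=C(NS(=O)(=O)c1ccc(Cl)cc1)N1CCN(c2cc3c(cc2F)c(=O)c(C(=O)O)cn3C2CC2)CC1` gives 71 nM, and the step of no change at the digits printed from compound 2 to compound 1 (within the scatter) follows the change (4-chlorophenyl in place of 2-(trifluoromethyl)phenyl on a sulfonyl sulfur). Compound 3 `CCn1cc(C(=O)O)c(=O)c2cc(F)c(N3CCN(C(=N)NS(=O)(=O)c4ccccc4C(F)(F)F)CC3)cc21` gives 71 nM, with the step of no change at the digits printed from compound 2 to compound 3 (within the scatter); the two cores differ as follows: ethyl in place of cyclopropyl on an aromatic nitrogen. Compound 4 `CCn1cc(C(=O)O)c(=O)c2cc(F)c(N3CCN(C(=N)NS(=O)(=O)c4ccc(Cl)cc4)CC3)cc21` has not yet been measured in this assay. Among the compounds with values here, it differs from compound 3 by 4-chlorophenyl in place of 2-(trifluoromethyl)phenyl on a sulfonyl sulfur, which is the same change as the one made from compound 2 to compound 1, at a place described in the same words. Among the compounds shown this change occurs twice in all, and its one measured step is no change at the digits printed from compound 2 to compound 1 (within the scatter). On the core of compound 3 the step is expected to be no change at the digits printed from compound 3 to compound 4 (within the scatter), resting on compound 2 having shown no change at the digits printed from compound 2 to compound 1 (within the scatter) for the same change. Compound 4 is therefore estimated at 71 nM in this assay, with an expected range from 35 nM to 140 nM.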

Compound 4, half-maximal inhibitory concentration: 71 nM
Compound 4: middle estimate and measured number agree at the digits printed, and the stated range covers the measured number.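

In this assay the change to 4-chlorophenyl in place of 2-(trifluoromethyl)phenyl on a sulfonyl sulfur gives no change at the digits printed from compound 3 to compound 4 (within the scatter), in line with the same change on the core of compound 2: the same change on two cores in this assay, no change at the digits printed (within the scatter) from compound 2 to compound 1 and no change at the digits printed (within the scatter) from compound 3 to compound 4, 1.0-fold (0.00 log units) apart, within the scatter of two such steps

Read the other way round the square, ethyl in place of cyclopropyl on an aromatic nitrogen gives no change at the digits printed from compound 1 to compound 4 (within the scatter), in line with its earlier step: the same change on two cores in this assay, no change at the digits printed (within the scatter) from compound 2 to compound 3 and no change at the digits printed (within the scatter) from compound 1 to compound 4, 1.0-fold (0.00 log units) apart, within the scatter of two such steps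

This shows that both changes carry between these cores without a detectable difference, but all four compounds are level, so only a null step has been carried, and nothing shows whether a step of real size would carry in the same way or why these steps are null.

As far as these compounds go, whether a methyl group on the sulfonyl sulfur or a longer chain such as propyl on the aromatic nitrogen would keep the number level remains open. Also open, from the compounds shown here alone, is what an amide in place of the carboxylic acid would do on either core.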